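Cytotoxicity of a Shared Core: Prenyl Gives Way to Chlorobenzyl

The source may hold more compounds than are shown below. What is called first, only, known or untested is meant among the compounds shown, and "the series" means these compounds.

Compound 1 `CC(C)=CCN1C(=O)N(Cc2ccccc2)S(=O)(=O)n2cccc21`: in an ADME assay on MT4 cells (Homo sapiens) for cytotoxicity, read by MTT assay, with a stated time of 5 days (on this read-out lower numbers stand for higher toxicity in this test and higher numbers for lower toxicity in this test), compound 1 gives 226000 nM.
Compound 2 `N#Cc1ccccc1CN1C(=O)N(Cc2cccc(F)c2)S(=O)(=O)n2cccc21`: in this assay compound 2 gives only a limit of the assay, > 305000 nM.

For the measured compounds named here, compound 1 holds the only full number in this assay; the other value recorded is a limit, as the limit of > 305000 nM in this assay, at which 1 of the 2 values shown sits, shows, so compound 1 cannot be ranked against compound 2 beyond saying that compound 2 sits at that limit. Compound 3 `O=C1N(Cc2ccccc2Cl)c2cccn2S(=O)(=O)N1Cc1ccccc1` has not yet been measured in this assay. It differs from compound 1 in one place: 2-chlorophenyl in place of 2-methylprop-1-en-1-yl on a saturated chain carbon bound to an amide-type nitrogen in a ring. The two compounds share the remaining core and the benzyl on the other ring nitrogen.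

Going by the values given here, with no step between measured compounds at hand, the expectation for this change rests on the two values alone, and no shift beyond the usual scatter is expected for the step of a 1.1-fold higher number from compound 1 to compound 3 (0.04 log units; within the scatter) in this assay. Compound 3 is therefore estimated to give 250000 nM in this assay, with a likely range from 120000 nM to 400000 nM, and with a fair chance that this assay again reports only a limit rather than a number.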

Compound 3, half-maximal cytotoxic concentration: > 291000 nM
Compound 3 was reported as a limit (the forecaster's own chance of this, stated with the estimate: 40%); middle value at least 1.1-fold (0.06 log units) away from the limit.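

Setting 2-chlorophenyl in place of 2-methylprop-1-en-1-yl on a saturated chain carbon bound to an amide-type nitrogen in a ring gives, in this assay, an at least 1.2-fold higher number from compound 1 to compound 3 (0.10 log units; that floor lies within the scatter). For compound 3 the read-out is a limit and not a number, so this step has a floor and no measured size: the limit of > 291000 nM in this assay, at which 1 of the 3 values shown sits. For the compounds shown here, this is the first direct reading at this position, and it shows that when the open chain with its double bond gives way to a six-membered aromatic ring of carbon only, the read-out ends at a limit rather than at a full number.

Whether the true step between these two compounds lies beyond the usual scatter can be neither claimed nor excluded from these values. Also open, on these data alone, is whether an amine, a carboxylic acid or a longer chain at this position would bring the read-out in this assay back to a full number.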